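Swapping a Dimethoxypropyl Chain for Cyclopentyl

A few compounds are considered here, and "the series" means these few. Any claim that something is new, unique, unknown or untested is made for them only; others in the source may bear on it.

Of the compounds shown here, three have so far been tested in a functional assay on HepG2 cells (Homo sapiens) for antiproliferative activity, read by CCK-8 assay, with a stated time of 72 h, tested at 2 uM; a higher number here means a stronger effect of the compound at the concentration tested, a lower number a weaker effect. Compound 1 `Nc1ccccc1NC(=O)c1ccc(Cn2cnc3c(Nc4ccccc4)nc(Cl)nc32)cc1` gives 49.6%, compound 3 `Nc1ccccc1NC(=O)c1ccc(COCNc2nc(Nc3cccc(Cl)c3)c3ncn(C4CCCC4)c3n2)cc1` gives 32.6%, and compound 2 `COC(CCn1cnc2c(NCc3ccc(C(=O)Nc4ccccc4N)cc3)nc(Cl)nc21)OC` gives 8.52%, the lowest of the three and beyond the scatter below both others. Compound 4 `Nc1ccccc1NC(=O)c1ccc(CNc2nc(Cl)nc3c2ncn3C2CCCC2)cc1` differs from compound 2 in one place: cyclopentyl in place of 3,3-dimethoxypropyl on an aromatic nitrogen. Compound 3, which also carries a cyclopentyl on an aromatic nitrogen of its core, sits clearly above compound 2, so a rise of moderate size is expected in this assay for compound 4, as the step of a number 19.5 percentage points higher from compound 2 to compound 4 (beyond the scatter) expresses. On this basis compound 4 is estimated to give 28%, with a plausible range from 10% to 48%.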

Compound 4, a percentage reported as inhibition, at one concentration (the size of the read-out at that concentration, not a potency): 54.7%
Beside the measured number, compound 4's estimate is 26.7 percentage points below it; the measured number lies above the stated range.
By their numbers in this assay, from the lowest: compound 2; then compound 3; then compounds 1 and 4 (each within the scatter of the next).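

In this assay, among these compounds, the step of a number 46.2 percentage points higher from compound 2 to compound 4 (beyond the scatter) is the first change in one place that can be read here, and it is large. It shows that the group on this aromatic nitrogen strongly affects the read-out: 3,3-dimethoxypropyl, an open chain with two hydrogen-bond acceptors, leaves for cyclopentyl, a carbon-only ring with none. Nothing available explains the size of this step.

From the compounds shown here alone, whether the rise follows from losing the two oxygens or from gaining the ring remains open. A plain propyl chain or a cyclohexyl ring at this position would separate the two.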